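Carbamate Variation on a Piperazine-Linked Quinazoline Kinase Inhibitor

The source may hold more compounds than are shown below. What is called first, only, known or untested is meant among the compounds shown, and "the series" means these compounds.

Measured so far:
compound 1 `CC(C)C(=O)OCOC(=O)N1CCN(C(=O)c2nc(Nc3cc(C4CC4)[nH]n3)c3cc(Cl)ccc3n2)C[C@H]1C`: 51.6%
compound 2 `C[C@@H]1CN(C(=O)c2nc(Nc3cc(C4CC4)[nH]n3)c3cc(Cl)ccc3n2)CCN1C(=O)OCC(Cl)(Cl)Cl`: 63%

In an assay for inhibition of serine/threonine-protein kinase PAK 4 (Homo sapiens), read by FRET and Z'-LYTE, with a stated time of 60 min, tested at 5 uM, in the presence of a further agent that is not named here (a higher number here means a stronger effect of the compound at the concentration tested, a lower number a weaker effect), compound 2 stands highest of the two numbers, with compound 1 the nearest at 51.6%. For the measured compounds named here, the single step of a number 11.4 percentage points higher from compound 1 to compound 2 (beyond the scatter) is the only one that bears on the change now considered. Compound 3 `C[C@@H]1CN(C(=O)c2nc(Nc3cc(C4CC4)[nH]n3)c3cc(Cl)ccc3n2)CCN1C(=O)OCOC(=O)C(C)(C)C` differs from compound 2 by ((tert-butyl)carbonyl)oxy in place of trichloromethyl on a saturated chain carbon bound to an oxygen next to a carbonyl group. Since this largely reverses the change that gave the earlier gain, a downward step of similar size is expected, a number 10 percentage points lower from compound 2 to compound 3 (within the scatter). Compound 3 is therefore estimated at 53%, with a range from 40% to 66%.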

Compound 3, a percentage reported as inhibition, at one concentration (the size of the read-out at that concentration, not a potency): 24.1%
The estimate for compound 3 lay 28.9 percentage points above the measured number; the measured number lies below the stated range.
By their numbers in this assay, from the lowest: compound 3; then compound 1; then compound 2.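

In this assay the position proves sensitive to more than the swap of trichloromethyl for an ester: ((tert-butyl)carbonyl)oxy in place of trichloromethyl gives a number 38.9 percentage points lower from compound 2 to compound 3 (beyond the scatter) and leaves compound 3 lowest of the three. The ester end itself also matters, since methyl in place of hydrogen on the saturated chain carbon bound to a carbonyl carbon and two saturated chain carbons gives a number 27.5 percentage points lower from compound 1 to compound 3 (beyond the scatter). Nothing measured here accounts for either step. As far as these compounds go, how acetyloxy or a plain methyl in the same place would read remains open.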